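Thioether replacement on compound 1: fluorobenzyl to pyridinylethyl

The source may report more compounds than this note shows. Statements on the series, on what has been measured and on what is new or still open speak of the compounds shown alone.

Measured compounds:
- compound 1, `O=c1c2cn(C3COC3)nc2nc(SCc2cccc(F)c2)n1-c1ccccc1`: 0.383 h
- compound 2, `CC(Sc1nc2c(cnn2C)c(=O)n1-c1ccccc1)c1cccc(F)c1`: 0.133 h
- compound 3, `Cn1ncc2c(=O)n(-c3ccccc3)c(SCc3cccc(F)c3)cc21`: 0.15 h

In an ADME assay on microsomes from liver (Mus musculus, strain CD-1) for metabolic stability, read by LC-MS, with a stated time of 60 min, tested at 20 uM (a higher number here means that the compound lasts longer, a lower number that the compound disappears faster), compound 1 gives 0.383 h, the highest of the three numbers recorded. Its nearest neighbour on the numbers is compound 3 at 0.15 h, and the furthest is compound 2 at 0.133 h; both gaps lie beyond the scatter of the assay, so compound 1 stands apart from the other two. No pair among these three differs in only one place, so no single step is available to lean on.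

Compound 4 is `CC(Sc1nc2nn(C3COC3)cc2c(=O)n1-c1ccccc1)c1ccccn1`. It differs from compound 1 in one place: 1-(pyridin-2-yl)ethyl in place of 3-fluorobenzyl on a sulfur. Compound 2 also carries a branched ethyl on its sulfur, but it differs from compound 1 elsewhere too; the value of compound 2, 0.133 h, only shows where such a compound can land and cannot be read as a step.

With nothing closer to go on, the expected step in this assay is a 1.5-fold lower number from compound 1 to compound 4 (0.19 log units; within the scatter), modestly downward and not clearly beyond the scatter. Compound 4 is therefore estimated at 0.25 h, with a range from 0.08 h to 0.7 h.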

Compound 4, half-life: > 1 h
Compound 4: only a limit was reported; the forecaster's own chance of this, stated with the estimate: 5%; middle value at least 4.0-fold (0.60 log units) away from the limit.
By their numbers in this assay, from the lowest: compounds 2 and 3 (each within the scatter of the next); then compound 1. At a limit, above all of these: compound 4.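

In this assay, among the compounds shown here, the group on the sulfur proves to matter with the rest of compound 1 held fixed: 1-(pyridin-2-yl)ethyl in place of 3-fluorobenzyl gives an at least 2.6-fold higher number from compound 1 to compound 4 (0.41 log units; beyond the scatter), the first single-place step. Compound 4 is reported only as a limit, > 1 h, so the full size of this step stays unfixed: the limit of > 1 h in this assay, at which 1 of the 4 values shown sits.

A single change at this place is therefore enough to raise the half-life beyond the scatter.

The change brings in the branched ethyl and the pyridine ring together, so the compounds shown cannot assign the step to either part. Open comparisons on the core of compound 1 are an unbranched pyridin-2-ylmethyl and a branched 1-(3-fluorophenyl)ethyl, which would separate the two.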